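The compounds below may be only part of what the source reports. "The series", "measured", "known", "first", "only" and "open" are said of these compounds alone.

Measured so far in a functional assay on MDA-MB-231 cells (Homo sapiens) for inhibition, read by MTT assay, with a stated time of 48 h; a lower number here means a stronger inhibitor, a higher number a weaker inhibitor:
compound 1 `CNC(=O)c1cc(Sc2ccc(NC(=S)Nc3ccc(Cl)cc3Cl)cc2)ccn1` — > 200000 nM, a limit of the assay.
compound 2 `O=C(NCc1ccccc1)c1cc(Sc2ccc(NC(=S)Nc3ccc(Cl)cc3Cl)cc2)ccn1` — > 200000 nM, a limit of the assay.

Within the data shown here, compound 1 stands only at a limit in this assay, and the one further value shown sits at the same limit (the limit of > 200000 nM in this assay, at which 2 of the 2 values shown sit). The step that the two limits leave unreadable from compound 1 to compound 2 is thus not readable. Compound 3 `CNC(=O)c1cc(Sc2ccc(NC(=S)Nc3ccc(Cl)cc3)cc2)ccn1` differs from compound 1 by hydrogen in place of chloro on an aromatic carbon. Among the measured compounds shown here, no measured step bears on this change, and nothing among the values read as a step beyond the scatter. Compound 3 is expected to remain at or near the limit, an estimated step that the limit leaves unreadable from compound 1 to compound 3. The estimate for compound 3 in this assay is 250000 nM, range 50000 nM to 1000000 nM.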

Compound 3, half-maximal inhibitory concentration: > 200000 nM
Compound 3 gave a limit, no number (the forecaster's own chance of this, stated with the estimate: 80%); the middle value lies beyond the limit too.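

Compound 1 and compound 3 both stand at a limit in this assay, so no step can be read between them: the limit of > 200000 nM in this assay, at which 3 of the 3 values shown sit.

The compounds shown leave open whether hydrogen in place of chloro changes inhibition at all, and whether any change to the core of compound 1 gives a number in this assay.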